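The compounds below may be only part of what the source reports. "The series", "measured", "known", "first", "only" and "open" are said of these compounds alone.

Compound 3 `COc1cc(/C(Cl)=C/C=C(\C#N)C(=O)c2c[nH]c3ccc(Br)cc23)cc(OC)c1OC` is the stronger inhibitor of growth of the two compounds that have a number in an ADME assay on Vero cells (Chlorocebus sabaeus) for cytotoxicity, read by sulforhodamine B assay, with a stated time of 48 h; a higher number here means a weaker inhibitor of growth, a lower number a stronger inhibitor of growth: compound 3 gives 7600 nM, while compound 1 `COc1cc(/C(Cl)=C/C=C(\C#N)C(=O)c2c[nH]c3ccccc23)cc(OC)c1OC` gives 16200 nM. Within the data shown here, the only step within the measured set, a 2.1-fold lower number from compound 1 to compound 3 (0.33 log units; beyond the scatter), comes from bromo in place of hydrogen on an aromatic carbon. For compound 2 `COc1ccc2[nH]cc(C(=O)/C(C#N)=C/C=C(\Cl)c3ccc(OC)c(OC)c3)c2c1` this assay gives "not determined" (no result reported).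

Compound 4 `COc1ccc(/C(Cl)=C/C=C(\C#N)C(=O)c2c[nH]c3ccc(Br)cc23)cc1OC` differs from compound 3 by hydrogen in place of methoxy on an aromatic carbon, in words hydrogen in place of methoxy on an aromatic carbon. Among the measured compounds shown here, none of the measured steps touches this part of the molecule, and the single step that exists concerns a different ring, so the data offer nothing that bears directly on this change. Without a comparable change to lean on, the expected step for compound 4 is no change at the digits printed from compound 3 to compound 4 (within the scatter), that is, no change beyond the scatter. Compound 4 is therefore estimated at 7600 nM, within a range of 3500 nM to 16500 nM.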

Compound 4, concentration for 50% growth inhibition: 8200 nM
Estimate against measurement, compound 4: 1.1-fold (0.03 log units) below; low and high end bracket the measured number.
By their numbers in this assay, from the lowest: compounds 3, 4 and 1 (each within the scatter of the next, the first and the last beyond it).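

Replacing the methoxy group ortho to a methoxy group with hydrogen gives a 1.1-fold higher number from compound 3 to compound 4 (0.03 log units; within the scatter) in this assay. Among these compounds, this is the first look at the ring carrying the methoxy groups, and it shows that, with the bromo group in place, this methoxy group can be lost without a change that stands out from the normal spread of repeat measurements. The measured data offer no explanation for why the number holds steady at this position.

Going by these compounds, it remains open whether the same swap would look equally flat in compound 1, which has hydrogen where compound 3 has bromo. Also open, on these data alone, is whether a group of a very different kind on this carbon, such as an amine or a carboxylic acid, would leave the number where it is.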